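Quinoline thiosemicarbazone: aryl on the amide-type nitrogen

The source may hold more compounds than are shown below. What is called first, only, known or untested is meant among the compounds shown, and "the series" means these compounds.

Measured so far:
compound 1 `NC(=S)N/N=C/c1ccc2ccccc2n1`: 960 nM
compound 2 `CN(C)C(=S)N/N=C/c1cnc2ccccc2n1`: 750 nM

Both compounds were tested in a functional assay on HeLa cells (Homo sapiens) for antiproliferative activity, read by sulforhodamine B assay, with a stated time of 72 h; on this read-out lower numbers stand for stronger inhibition and higher numbers for weaker inhibition. Compound 1 gives 960 nM, the highest of the two numbers shown, while compound 2 gives 750 nM; the two values lie within the scatter of each other, so no order between them can be stated. Compound 3 `COc1ccccc1NC(=S)N/N=C/c1ccc2ccccc2n1` has not yet been measured. It differs from compound 1 by 2-methoxyphenyl in place of hydrogen on an amide-type nitrogen. Within the data shown here, no step between measured compounds that differ in one place is available, so the size of this change has no measured counterpart here. A modest step toward a lower number in this assay is expected, from compound 1 to compound 3 a 2.1-fold lower number from compound 1 to compound 3 (0.33 log units; beyond the scatter), though one that may not exceed the scatter. Compound 3 is therefore estimated at 450 nM, with a range from 120 nM to 1800 nM.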

Compound 3, half-maximal inhibitory concentration: > 100000 nM
Compound 3 ended at the assay's limit (the forecaster's own chance of this, stated with the estimate: 3%); middle value at least 220-fold (2.34 log units) from the limit.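

Among these compounds, the change from hydrogen to 2-methoxyphenyl on the amide-type nitrogen gives, in this assay, an at least 100-fold higher number from compound 1 to compound 3 (2.01 log units; beyond the scatter), the first step between compounds that differ in one place. It shows that this nitrogen is not a neutral point of the shared core: this single replacement is enough to carry the read-out from the high-nanomolar level of compound 1 to the end of the measurable range. The value of compound 3 is a limit of the assay and not a number, so the true size of the step stays unknown: the limit of > 100000 nM in this assay, at which 1 of the 3 values shown sits.

The compounds shown do not separate the contribution of the phenyl ring from that of its methoxy group, which a plain phenyl on this nitrogen would address. They also leave open whether a smaller group, such as methyl, or a short chain ending in an amine would be accepted here.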